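The compounds below may be only part of what the source reports. "The series", "measured", "known", "first", "only" and "open" are said of these compounds alone.

Measured so far in a functional assay on DU-145 cells (Homo sapiens) for antiproliferative activity, read by WST assay, with a stated time of 3 days; a higher number here means a weaker inhibitor, a lower number a stronger inhibitor:
Compound 1, `CCCCOc1c(-c2cc(OC)c(OC)c(OC)c2)oc2ccccc2c1=O` — compound 1 gives > 50000 nM, a limit of the assay and not a number.
Compound 2, `CCCCCCOc1c(-c2cc(OC)c(OC)c(OC)c2)oc2ccccc2c1=O` — compound 2 gives > 50000 nM, likewise a limit of the assay.

Compound 2 thus stands at the limit, where (the limit of > 50000 nM in this assay, at which 2 of the 2 values shown sit). Compound 3, `CCCCN(CCCC)CCCCCOc1c(-c2cc(OC)c(OC)c(OC)c2)oc2ccccc2c1=O`, differs from compound 2 by dibutylamino in place of methyl on a saturated chain carbon, five bonds along the chain from an oxygen on an aromatic ring. The only measured step, a step that the two limits leave unreadable from compound 1 to compound 2, runs between two limits and gives no readable size, so no measured step bears on the change to compound 3 and the numbers shown fix no direction for it in this assay. Compound 3 is estimated at 25000 nM, within 3000 nM to 50000 nM. The step of an at least 2.0-fold lower number from compound 2 to compound 3 (0.30 log units; that floor lies within the scatter) is expected, with a real chance that only a limit is reported.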

Compound 3, half-maximal inhibitory concentration: > 50000 nM
Compound 3: a limit, no number; the forecaster's own chance of this, stated with the estimate: 45%; middle value at least 2.0-fold (0.30 log units) away from the limit.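

Compound 3, like compound 1 and compound 2, gives only a limit and no number, so no step among the three can be read: the limit of > 50000 nM in this assay, at which 3 of the 3 values shown sit.

The compounds shown leave open how any of these chains, with or without dibutylamino, would rank in this assay.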